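Aryl ether to aryl thioether on the shared core

This account rests on a few compounds, and the source may have more. Where it says the series, first, only, none or still open, it means among the compounds named here.

Measured so far:
compound 1, `Nc1cc(N)c2nc(-c3ccccc3)c(Oc3ccc(F)cc3)nc2c1` — < 100000 nM
compound 2, `CCOC(=O)[C@H](CCC(=O)O)NC(=O)c1ccc(Oc2nc3cc(N)cc(N)c3nc2-c2ccccc2)cc1` — 26300 nM

Both compounds were read in a functional assay on LOX IMVI cells (Homo sapiens) for inhibition, read by sulforhodamine B assay, with a stated time of 48 h; a lower number here means a stronger inhibitor of growth, a higher number a weaker inhibitor of growth. For compound 1 the result < 100000 nM is a limit of the assay and not a number, the one result that sits at the limit of < 100000 nM in this assay, at which 1 of the 2 values shown sits. Compound 2 gives 26300 nM in this assay, a number inside the measured range. Within the data shown here, no pair of measured compounds differs in one place, so no measured step is available on the shared core.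

Compound 3, `COc1ccc(Sc2nc3cc(N)cc(N)c3nc2-c2ccccc2)cc1`, is the next compound for this assay. It differs from compound 1 in one place: (4-methoxyphenyl)sulfanyl in place of 4-fluorophenoxy on an aromatic carbon. Since compound 1 stands only at a limit, the step from it cannot be sized from the data. The expectation is a step that the limit leaves unreadable from compound 1 to compound 3, meaning a value in the same broad region where compound 2 sits, with a wide range on either side. Compound 3 is therefore estimated at 30000 nM, between 6000 nM and 100000 nM, with a fair chance that this assay again reports only a limit.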

Compound 3, concentration for total growth inhibition: < 100000 nM
Compound 3 was reported as a limit (the forecaster's own chance of this, stated with the estimate: 30%); the middle value lies beyond the limit too.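

In this assay compound 3 gives < 100000 nM, a limit of the assay and not a number. No step can be read between compound 1 and compound 3 because both stand at a limit: the limit of < 100000 nM in this assay, at which 2 of the 3 values shown sit.

The compounds shown leave open how far (4-methoxyphenyl)sulfanyl in place of 4-fluorophenoxy on the shared core shifts the result in this assay, if at all.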